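The compounds below may be only part of what the source reports. "The series", "measured", "known", "first", "only" and "open" are said of these compounds alone.

Of the compounds shown here, three built on one shared core have been tested in a functional assay on PC-3 cells (Homo sapiens) for cytotoxicity, read by MTT assay, with a stated time of 72 h; on this read-out lower numbers stand for stronger inhibition and higher numbers for weaker inhibition. Compound 1 `COc1ccccc1Nc1nc(SCc2ccc(C(F)(F)F)cc2)nc2ccccc12` gives 14100 nM in this assay. Compound 2 `COc1ccc(Nc2nc(SCc3ccc(C(F)(F)F)cc3)nc3ccccc23)c(OC)c1` differs from it by methoxy in place of hydrogen on an aromatic carbon and gives 32500 nM; that step, a 2.3-fold higher number from compound 1 to compound 2 (0.36 log units; beyond the scatter), means a weaker effect. Compound 3 `COc1ccc(Nc2nc(SCc3ccc(C(F)(F)F)cc3)nc3ccccc23)cc1OC` carries a different substituted phenyl group on the nitrogen, the difference being (3,4-dimethoxyphenyl in place of 2-methoxyphenyl on a nitrogen on an aromatic ring), and gives 14100 nM; the comparison no change at the digits printed from compound 1 to compound 3 (within the scatter) shows no difference that can be trusted, while a 2.3-fold lower number from compound 2 to compound 3 (0.36 log units; beyond the scatter) shows compound 3 somewhat stronger than compound 2.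

Compound 4 `COc1cc(Nc2nc(SCc3ccc(C(F)(F)F)cc3)nc3ccccc23)cc(OC)c1OC` has not yet been measured in this assay. Relative to compound 3 it carries methoxy in place of hydrogen on an aromatic carbon. For the measured compounds named here, this is the same kind of change as the one from compound 1 to compound 2, but not the same: in compound 2 the new methoxy sits meta to a methoxy group and para to a large group, whereas in compound 4 it sits ortho to a methoxy group, meta to a large group and meta to a methoxy group. Going by the values given here, the only guide is that adding a methoxy made compound 2 weaker than compound 1, as seen in a 2.3-fold higher number from compound 1 to compound 2 (0.36 log units; beyond the scatter). On that basis a step of about a 1.8-fold higher number from compound 3 to compound 4 (0.27 log units; within the scatter) is expected from compound 3 to compound 4. Compound 4 is therefore estimated at 26000 nM in this assay, most likely between 12000 nM and 55000 nM.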

Compound 4, half-maximal inhibitory concentration: 7370 nM
The estimate for compound 4 lay 3.5-fold (0.55 log units) above the measured number, outside the stated range (below it).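

Adding a methoxy gives a 1.9-fold lower number from compound 3 to compound 4 (0.28 log units; within the scatter), so in this assay compound 3 and compound 4 cannot be told apart, whereas the same kind of addition on compound 1 gave a real, if modest, loss of effect. A methoxy in place of hydrogen therefore does not bring the same result wherever it is added in this series, and the loss seen with the first pair cannot simply be carried over to the second: the same change on two cores in this assay, a 2.3-fold higher number (0.36 log units; beyond the scatter) from compound 1 to compound 2 and a 1.9-fold lower number (0.28 log units; within the scatter) from compound 3 to compound 4, 4.4-fold (0.64 log units) apart, beyond the scatter of two such steps

For the compounds shown here, this rests on only two pairs, and the new methoxy lands in a different place on the aromatic ring in each, so the data cannot say whether the gap comes from that place, from the groups already on the ring, or from both, and they do not show that the added methoxy in compound 4 helps.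

From the compounds shown here alone, all four compounds carry only methoxy groups on the phenyl ring attached to the nitrogen, so it remains open how a longer chain such as ethoxy, an amine or a carboxylic acid on that ring would read in this assay. The trifluoromethyl-bearing side of the molecule is also the same throughout, so these numbers say nothing about changing it.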